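Swapping a sulfur-bearing group for a nitrogen-rich one

This account rests on a few compounds, and the source may have more. Where it says the series, first, only, none or still open, it means among the compounds named here.

Compounds measured:
compound 1, `CC/N=C(\S)NCCCCCCn1nc(-c2ccccc2)ccc1=O`: -5.6%
compound 2, `C/N=C(/NC#N)NCCCCCn1nc(-c2ccccc2)ccc1=O`: 47.6%
compound 3, `CC(C)(C)/N=C(\S)NCCCCn1nc(-c2ccccc2)ccc1=O`: 33.6%

In a functional assay on the whole organism with Rattus norvegicus as the target, at a dose of 100 mg/kg (a higher number here means more inhibition at the dose given (going by the name of the read-out), a lower number less inhibition), compound 3 stands second highest of the three. It sits a number 14 percentage points lower from compound 2 to compound 3 (beyond the scatter), and it lies well above compound 1, as the step of a number 39.2 percentage points higher from compound 1 to compound 3 (beyond the scatter) shows.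

Compound 4, `C/N=C(/NC#N)N(C)CCCCn1nc(-c2ccccc2)ccc1=O`, has not yet been measured. It differs from compound 3 in one place: a group of 8 heavy atoms (4 carbon, 4 nitrogen; no ring) in place of a group of 8 heavy atoms (5 carbon, 2 nitrogen, 1 sulfur; no ring), on a saturated chain carbon, four bonds along the chain from an aromatic nitrogen

Within the data shown here, two measured steps bear on this change. The step of a number 53.2 percentage points higher from compound 1 to compound 2 (beyond the scatter) involves a swap of the same kind, with a group holding four nitrogen atoms entering in place of one holding a sulfur atom. The step of a number 14 percentage points lower from compound 2 to compound 3 (beyond the scatter) runs the other way, sulfur replacing the nitrogen-rich group. Both point the same direction: the nitrogen-rich group goes with a higher inhibition. For compound 4 a rise is therefore expected, of a size like a number 13.4 percentage points higher from compound 3 to compound 4 (beyond the scatter), and compound 4 is estimated at 47%, with a range from 27% to 67%.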

Compound 4, a percentage reported as inhibition, in the whole organism at one dose (the size of the read-out at that dose, not a potency): 27%
Beside the measured number, compound 4's estimate is 20 percentage points above it, within the range that was stated.
By their numbers in this assay, from the lowest: compound 1; then compounds 4 and 3 (each within the scatter of the next); then compound 2.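

In this assay, the swap at this place gives a number 6.6 percentage points lower from compound 3 to compound 4 (within the scatter), so the sulfur-bearing group and the group of 4 carbon and 4 nitrogen atoms cannot be told apart here, and the nitrogen-rich group brings no gain by itself. Two groups with the same heavy atoms can still differ, as a number 20.6 percentage points lower from compound 2 to compound 4 (beyond the scatter) shows, so the atom count alone does not set the number. The gain seen in a number 32.6 percentage points higher from compound 1 to compound 4 (beyond the scatter) is large, yet compound 3 also carries sulfur and stands within the scatter of compound 4, so sulfur alone cannot account for the low number of compound 1.

Nothing available explains these differences. Going by these compounds, whether an amine or a carboxylic acid at this place, or a longer chain bearing the group of compound 4, would shift the inhibition remains open.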